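The compounds below may be only part of what the source reports. "The series", "measured", "known", "first", "only" and "open" are said of these compounds alone.

Compound 2 `O=C1c2ccc(C#Cc3cccnc3)nc2CCN1C1CCCC1` carries a pyridin-3-yl group on the triple-bonded carbon of the shared core, and in a functional assay on HEK293 cells for positive allosteric modulation of metabotropic glutamate receptor 5 (Homo sapiens), read by FLIPR and calcium flux (on this read-out lower numbers stand for an effect already at smaller amounts and higher numbers for an effect only at larger amounts of compound), compound 2 gives 748 nM. Among the two compounds measured so far, compound 2 stands at the higher end: compound 1 `O=C1c2ccc(C#Cc3cccc(Cl)c3)nc2CCN1C1CCCC1`, which bears a 3-chlorophenyl group at the same position, gives 33 nM in this assay, and the single measured step, a 23-fold higher number from compound 1 to compound 2 (1.36 log units; beyond the scatter), shows how strongly the read-out responds to what sits on that triple-bonded carbon.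

Compound 3 `O=C1c2ccc(C#Cc3cccs3)nc2CCN1C1CCCC1` differs from compound 2 by thiophen-2-yl in place of pyridin-3-yl on a triple-bonded carbon. For the measured compounds named here, no measured step covers a thiophen-2-yl group, so the only guide is the large swing seen from compound 1 to compound 2, which indicates that a change at this position can move the number well beyond the scatter. A step of moderate size toward a lower number is therefore expected for compound 3 in this assay, a 5.0-fold lower number from compound 2 to compound 3 (0.70 log units; beyond the scatter). Compound 3 is estimated at 150 nM, with a range from 40 nM to 600 nM.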

Compound 3, half-maximal effective concentration: 12 nM
Compound 3: middle estimate off by 13-fold (1.10 log units), on the high side, outside the stated range (below it).
By their numbers in this assay, from the lowest: compound 3; then compound 1; then compound 2.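

In this assay, compound 3 shows that a five-membered aromatic ring on the triple-bonded carbon can bring the number below those of both six-membered groups seen so far, and the change from pyridin-3-yl to thiophen-2-yl gives a 62-fold lower number from compound 2 to compound 3 (1.79 log units; beyond the scatter) in a single exchange. A low number at this position is also not tied to the 3-chlorophenyl group, since the comparison of the two groups that read low gives a 2.8-fold lower number from compound 1 to compound 3 (0.44 log units; beyond the scatter) and so still lies beyond the scatter. The counts alone do not sort the groups either: pyridin-3-yl and thiophen-2-yl each carry one hetero atom and one hydrogen-bond acceptor, yet they stand at opposite ends of the three compounds.

No evidence is available to say what separates these groups. Still open, on these data alone, is whether the low number is particular to thiophen-2-yl or extends to other groups at this position, such as thiophen-3-yl, furan-2-yl, an unsubstituted phenyl or a saturated ring such as cyclohexyl.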